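The source may report more compounds than this note shows. Statements on the series, on what has been measured and on what is new or still open speak of the compounds shown alone.

Compound 1 `O=C(/C=C/C1=Cc2ccccc2OC1)c1ccccc1F` and compound 2 `O=C(/C=C/C1=Cc2ccccc2OC1)c1ccccc1Cl` share one core and differ at a single aromatic carbon. In a functional assay on the whole organism for inhibition, with Mus musculus as the target, with a stated time of 1 h, at a dose of 30 mg/kg by the intraperitoneal route (on this read-out lower numbers stand for less inhibition and higher numbers for more inhibition at the one dose given (going by the name of the read-out)), compound 1 gives 64.4%, and compound 2 gives 52.3%, the lower of the two numbers. The step of a number 12.1 percentage points lower from compound 1 to compound 2 (beyond the scatter) is modest but beyond the usual scatter. Compound 3 `O=C(/C=C/C1=Cc2ccccc2OC1)c1ccccc1Br` differs from compound 2 by bromo in place of chloro on an aromatic carbon. For the measured compounds named here, the only measured step bearing on this change is that modest one, and a similar small fall is expected for compound 3, a step of a number 8.3 percentage points lower from compound 2 to compound 3 (within the scatter). Compound 3 is therefore estimated at 44%, within 30% to 58%.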

Compound 3, a percentage reported as inhibition, in the whole organism at one dose (the size of the read-out at that dose, not a potency): 56.6%
For compound 3 the middle estimate is 12.6 percentage points below the measured one; measured number inside the range.
By their numbers in this assay, from the lowest: compounds 2, 3 and 1 (each within the scatter of the next, the first and the last beyond it).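

Bromo does not carry on the fall seen on going from fluoro to chloro: in this assay the record reads a number 4.3 percentage points higher from compound 2 to compound 3 (within the scatter) and a number 7.8 percentage points lower from compound 1 to compound 3 (within the scatter). Compound 3 therefore cannot be told apart from either neighbour, and only fluoro and chloro are separated at this aromatic carbon, so the halogens shown form no steady trend. Nothing available explains these numbers. The compounds shown leave open how a group other than a halogen, such as methoxy or an amine, would read on this carbon.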